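The source may report more compounds than this note shows. Statements on the series, on what has been measured and on what is new or still open speak of the compounds shown alone.

Series notes, agonist read-out. Compound 1 `CC(C)OC(=O)N1CCC(Oc2ncnc3c2CCN3c2ccc(S(C)(=O)=O)cc2)CC1` carries an isopropyl carbamate and in a functional assay on CHO-K1 cells for agonist activity at Glucose-dependent insulinotropic receptor (Homo sapiens), read by a luciferase reporter, with a stated time of 5 h (on this read-out lower numbers stand for an effect already at smaller amounts and higher numbers for an effect only at larger amounts of compound), gives 126 nM. Compound 2 `COC(=O)N1CCC(Oc2ncnc3c2CCN3c2ccc(S(C)(=O)=O)cc2F)CC1` carries a methyl carbamate and an added fluorine on the outer aryl ring; in this assay compound 2 gives 316 nM. Going by the values given here, of the two numbers known so far, compound 1 stands at the lower one; the gap to compound 2 lies beyond the usual scatter, but the two compounds differ in more than one place, so no single step can be read from that pair.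

Compound 3 `CSc1ccc(N2CCc3c(OC4CCN(C(=O)OC(C)C)CC4)ncnc32)cc1F` has not yet been measured. It keeps the isopropyl carbamate of compound 1 and differs from it by a group of 9 heavy atoms (7 carbon, 1 fluorine, 1 sulfur; one six-membered aromatic ring of carbon only) in place of a group of 10 heavy atoms (7 carbon, 2 oxygen, 1 sulfur; one six-membered aromatic ring of carbon only), on a nitrogen on an aromatic ring in a ring. Among the compounds with values here, no measured pair isolates this change, so the direction rests on the two values alone. The expected step of a 2.0-fold higher number from compound 1 to compound 3 (0.30 log units; within the scatter) is a modest rise in the number, with wide uncertainty. Compound 3 is estimated at 250 nM, in the range 80 nM to 800 nM.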

Compound 3, half-maximal effective concentration: 398 nM
Beside the measured number, compound 3's estimate is 1.6-fold (0.20 log units) below it, within the range that was stated.
By their numbers in this assay, from the lowest: compound 1; then compounds 2 and 3 (each within the scatter of the next).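

Going by these compounds alone, this is the first step that isolates a single place: on the nitrogen on an aromatic ring in a ring, with the isopropyl carbamate held constant, the swap of 4-(methylsulfonyl)phenyl for the group with one fluorine and one sulfur gives in this assay a 3.2-fold higher number from compound 1 to compound 3 (0.50 log units; beyond the scatter). The read-out therefore responds to a change at this place, and of the two aryl groups compared here, 4-(methylsulfonyl)phenyl goes with the lower number. No measurement available bears on the reason for this step.

Within the data shown here, the single step cannot separate the loss of the two oxygens from the entry of the fluorine, since both change together. Going by these compounds, how a nitrile or a primary sulfonamide in place of the methylsulfonyl group would read on this aryl ring remains open, as does the effect of the carbamate alone.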